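Replacing Phenyl with Trifluoromethyl: An Expected Small Shift

A few compounds are considered here, and "the series" means these few. Any claim that something is new, unique, unknown or untested is made for them only; others in the source may bear on it.

compound 1 `O=C(NCc1ccc(NC(=O)c2cc(-c3ccccc3)ccc2N2CCCC2)cc1)OCc1cccnc1` gives 4340 nM
compound 2 `O=C(NCc1ccc(NC(=O)c2cccc(F)c2N2CCCC2)cc1)OCc1cccnc1` gives 2020 nM

Going by the values given here, in a functional assay on HGC-27 cells (Homo sapiens) for inhibition, read by MTT assay, with a stated time of 72 h (on this read-out lower numbers stand for stronger inhibition and higher numbers for weaker inhibition), compound 1 stands highest of the two numbers so far, and compound 2, its nearest neighbour, reads lower by a gap beyond the scatter. The step followed here leads to compound 3 `O=C(NCc1ccc(NC(=O)c2cc(C(F)(F)F)ccc2N2CCCC2)cc1)OCc1cccnc1` in which trifluoromethyl takes the place of phenyl on an aromatic carbon, para to a pyrrolidin-1-yl group (trifluoromethyl in place of phenyl on an aromatic carbon). Among the compounds with values here, no two measured compounds differ in one place only, so the data hold no direct precedent for this change. Within the data shown here, compound 2 at 2020 nM and compound 1 at 4340 nM show only that a compound lacking the phenyl can read the smaller number of the two, and little more can be drawn from one pair. In this assay a small downward move is therefore expected, and the estimated step of a 1.4-fold lower number from compound 1 to compound 3 (0.16 log units; within the scatter) stays within the scatter. For compound 3 the expected value is 3000 nM with an estimated range from 1300 nM to 7000 nM on this read-out.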

Compound 3, half-maximal inhibitory concentration: 790 nM
Compound 3: middle estimate off by 3.8-fold (0.58 log units), on the high side, and the stated range ends above it.
By their numbers in this assay, from the lowest: compound 3; then compound 2; then compound 1.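

In this assay, going by these compounds alone, trifluoromethyl in place of phenyl on this aromatic carbon gives a 5.5-fold lower number from compound 1 to compound 3 (0.74 log units; beyond the scatter) and lies beyond the scatter, providing the first direct reading of a change made in one place only. The position, para to a pyrrolidin-1-yl group, is therefore not indifferent to the group it carries, and here the phenyl, a six-membered aromatic ring of 6 heavy atoms, can be given up for a ring-free group of 4 heavy atoms with a lower number on this read-out. No measurement bears on why the number moves, so the step records the outcome of the exchange without identifying which difference between the two groups matters.

Within the data shown here, the single step cannot separate the loss of the aromatic ring from the arrival of fluorine, and a methyl group, a chlorine atom or a nitrile on the same carbon would bear on that question. It also leaves open whether a larger group such as tert-butyl or a smaller one such as hydrogen would continue the same direction at this position, or whether the trend would reverse.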